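This account rests on a few compounds, and the source may have more. Where it says the series, first, only, none or still open, it means among the compounds named here.

Measured so far:
Compound 1 `Cc1ccccc1-c1cccc(NCc2cncn2Cc2ccccc2)c1`: > 1000 nM, a limit
Compound 2 `Cc1cccc(-c2cccc(NCc3cncn3Cc3ccccc3)c2)c1`: > 1000 nM, a limit

In a toxicity assay on NIH3T3 cells (Mus musculus) for cytotoxicity, read by resazurin assay (a higher number here means that more compound is needed for the effect, a lower number that less compound is needed), compound 2 stands at > 1000 nM, which is a limit of the assay and not a number. What the data show so far is the limit of > 1000 nM in this assay, at which 2 of the 2 values shown sit. Neither compound has given an actual number, so compound 2 can be placed only at this limit.

Compound 3 `c1ccc(Cn2cncc2CNc2cccc(-c3cccnc3)c2)cc1` carries pyridin-3-yl in place of 3-methylphenyl on an aromatic carbon.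

Among the compounds with values here, only one measured step bears on this change, and it swaps 2-methylphenyl for 3-methylphenyl: a step that the two limits leave unreadable from compound 1 to compound 2. It offers no size to carry over, so no step beyond the usual scatter is expected in this assay. Compound 3 is expected to be reported most likely as a limit again, though a real number close to that limit remains possible. The estimated change is a step that the limit leaves unreadable from compound 2 to compound 3. For compound 3 the expected half-maximal effective concentration is 1500 nM, with an estimated range from 500 nM to 8000 nM.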

Compound 3, half-maximal effective concentration: > 1000 nM
Compound 3 gave a limit, no number; the forecaster's own chance of this, stated with the estimate: 80%; the middle value is on the limit's open side.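

In this assay, no new step can be read between compound 3 and either compound 1 or compound 2, because all three are reported only as limits and not as numbers: the limit of > 1000 nM in this assay, at which 3 of the 3 values shown sit.

The compounds shown leave open how much of each is needed for the effect, and whether pyridin-3-yl in place of 3-methylphenyl changes that amount at all.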